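A few compounds are considered here, and "the series" means these few. Any claim that something is new, unique, unknown or untested is made for them only; others in the source may bear on it.

Measured so far in a functional assay on MGC-803 cells (Homo sapiens) for inhibition, read by MTT assay, with a stated time of 48 h; a lower number here means a stronger inhibitor, a higher number a weaker inhibitor:
- compound 1 `C/C=C/C(=O)N(Cc1ccc(OC)c(Br)c1)c1cc(OC)c(OC)c(OC)c1`: 6430 nM
- compound 2 `C/C=C/C(=O)N(Cc1ccc(OC)c(C)c1)c1cc(OC)c(OC)c(OC)c1`: 14500 nM
- compound 3 `C/C=C/C(=O)N(Cc1cccc(O)c1)c1cc(OC)c(OC)c(OC)c1`: 14100 nM

The two upper numbers of the three cannot be told apart: a 1.0-fold lower number from compound 2 to compound 3 (0.01 log units; within the scatter). Compound 3 therefore stands level with compound 2 at the upper end of this assay, and the remaining gap is a 2.2-fold higher number from compound 1 to compound 3 (0.34 log units; beyond the scatter).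

Compound 4 `C/C=C/C(=O)N(Cc1ccc(OC)c(Cl)c1)c1cc(OC)c(OC)c(OC)c1` is the next case, with 3-chloro-4-methoxyphenyl in place of 3-hydroxyphenyl on a saturated chain carbon bound to an amide-type nitrogen.

The nearest measured group is the 3-bromo-4-methoxyphenyl of compound 1, so the step of a 2.2-fold higher number from compound 1 to compound 3 (0.34 log units; beyond the scatter) bears most directly, read in reverse. The step of a 2.3-fold higher number from compound 1 to compound 2 (0.35 log units; beyond the scatter) shows a similar modest size for methyl in place of bromo on an aromatic carbon. Within the data shown here, no chloro compound has been measured, so the transfer from bromo to chloro remains untested.

A modest move towards a lower number is expected, no larger than these measured steps. The expected step is a 1.7-fold lower number from compound 3 to compound 4 (0.22 log units; within the scatter). Compound 4 is estimated at 8500 nM, with an expected range of 4500 nM to 15000 nM.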

Compound 4, half-maximal inhibitory concentration: 7100 nM
Beside the measured number, compound 4's estimate is 1.2-fold (0.08 log units) above it; low and high end bracket the measured number.
By their numbers in this assay, from the lowest: compounds 1, 4, 3 and 2 (each within the scatter of the next, the first and the last beyond it).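

Working notes on the series: in this assay, the change of halogen gives a 1.1-fold higher number from compound 1 to compound 4 (0.04 log units; within the scatter) and so separates the two halogens at this place by no measurable amount, a comparison the earlier compounds could not offer. Chloro in place of methyl on an aromatic carbon gives a 2.0-fold lower number from compound 2 to compound 4 (0.31 log units; beyond the scatter) and is a modest step, so among compounds 1, 2 and 4 both halogens give lower numbers than methyl, with no compound here going against that. The swap of 3-hydroxyphenyl for 3-chloro-4-methoxyphenyl gives a 2.0-fold lower number from compound 3 to compound 4 (0.30 log units; within the scatter) and thus stays unresolved, so compound 3 is separated from the bromo compound but not from its chloro counterpart.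

No supporting data offer an explanation for any of these steps. Open, as far as these compounds go, is how far the numbers would move with a 3-aminophenyl or a 3-carboxyphenyl in place of 3-chloro-4-methoxyphenyl on a saturated chain carbon bound to an amide-type nitrogen, and whether any such group would leave the narrow range seen so far.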